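Neutral Amide Chain in Place of an Azetidine Acid

This account rests on a few compounds, and the source may have more. Where it says the series, first, only, none or still open, it means among the compounds named here.

Measured so far:
Compound 1, `COc1ccc(/C=C\c2cc(OC)c(OC)c(OC)c2)cc1OCc1ccc(CN2CC(C(=O)O)C2)cc1`: > 10000 nM
Compound 2, `COc1ccc(/C=C\c2cc(OC)c(OC)c(OC)c2)cc1OCc1ccc(CN2CC[C@H](O)C2)cc1`: 7200 nM

Both compounds share one core and differ only in the group on a saturated chain carbon bound to an aromatic carbon. In a functional assay on MC-38 cells (Mus musculus) for antiproliferative activity, read by CCK-8 assay, with a stated time of 48 h (on this read-out higher numbers stand for weaker inhibition and lower numbers for stronger inhibition), compound 1 gives > 10000 nM, which is a limit of the assay and not a number. In this assay compound 2 gives 7200 nM. The step of an at least 1.3-fold lower number from compound 1 to compound 2 (0.14 log units; that floor lies within the scatter) stays within the scatter, so the two compounds cannot be ordered.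

Compound 3, `COc1ccc(/C=C\c2cc(OC)c(OC)c(OC)c2)cc1OCc1ccc(CNCCNC(C)=O)cc1`, differs from compound 1 in one place: (2-acetamidoethyl)amino in place of 3-carboxyazetidin-1-yl on a saturated chain carbon bound to an aromatic carbon. For the measured compounds named here, the only measured step that bears on this change is the one from compound 1 to compound 2, which did not leave the scatter, and compound 1 itself sits at a limit (the limit of > 10000 nM in this assay, at which 1 of the 2 values shown sits). No step beyond the scatter is therefore expected. Compound 3 is estimated at 8000 nM, with a range from 2000 nM to 30000 nM. This estimate corresponds to the expected step of an at least 1.2-fold lower number from compound 1 to compound 3 (0.09 log units; that floor lies within the scatter).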

Compound 3, half-maximal inhibitory concentration: 1800 nM
Compound 3: middle estimate off by 4.4-fold (0.65 log units), on the high side; the measured number lies below the stated range.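

For the compounds shown here, at this position, on a saturated chain carbon bound to an aromatic carbon, the result gives the first step between two real numbers that leaves the scatter in this assay: a 4.0-fold lower number from compound 2 to compound 3 (0.60 log units; beyond the scatter). Against the azetidine acid the result reads an at least 5.5-fold lower number from compound 1 to compound 3 (0.74 log units; beyond the scatter), so with both steps beyond the scatter, compound 3 is the most active of the three and the group at this position is shown to matter. Compound 1 gives > 10000 nM, which is a limit of the assay and not a number, so its step gives only a floor.

The compounds shown leave open whether the lower number goes with the acetamide or with the open chain. A (3-acetamidopropyl)amino group, with its longer chain, or a (2-aminoethyl)amino group, with a free amine in place of the acetamide, would help separate the two.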